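Quinoline sulfones at the metabotropic glutamate receptor 5

This account rests on a few compounds, and the source may have more. Where it says the series, first, only, none or still open, it means among the compounds named here.

Measured so far:
compound 1, `Cc1ccc(S(=O)(=O)c2cnc3cc(F)ccc3c2N2CCC(C)CC2)cc1C`, 90%
compound 2, `COc1ccc(S(=O)(=O)c2cnc3cc(Cl)ccc3c2N2CCC(C)CC2)cc1Cl`, 93%

Compound 2 stands at the top of these two numbers in an assay on isolated protein for displacement of a labelled ligand from metabotropic glutamate receptor 5 (Homo sapiens), with a stated time of 60 min, tested at 1 uM (a lower number here means less inhibition, a higher number more inhibition at the concentration tested (going by the name of the read-out)), yet compound 1 sits only a few points lower, and that gap lies within the scatter, so the two are not separated. Compound 3, `COc1ccc(S(=O)(=O)c2cnc3cc(Cl)ccc3c2N2CCC(C)CC2)cc1OC`, has not been measured. It differs from compound 2 by one change: methoxy in place of chloro on an aromatic carbon. The rest of the shared core, the aryl sulfone and the 4-methylpiperidine, is kept. Among the measured compounds shown here, no pair of measured compounds shows what such a swap does here, so the expectation rests on the high readings of both compounds 1 and 2 alone. A modest step downward, or none beyond the scatter, is expected, as a number 8 percentage points lower from compound 2 to compound 3 (within the scatter). Compound 3 is therefore estimated at 85%, within a range from 65% to 96%.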

Compound 3, a percentage reported as inhibition, at one concentration (the size of the read-out at that concentration, not a potency): 93%
Compound 3: the middle estimate sits 8 percentage points below what was measured; the measured number falls inside the stated range.
By their numbers in this assay, from the lowest: compounds 1, 2 and 3 (each within the scatter of the next).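

Putting methoxy in place of chloro on the aromatic carbon ortho to a methoxy group, which turns 3-chloro-4-methoxyphenyl into 3,4-dimethoxyphenyl, brings no change at the digits printed from compound 2 to compound 3 (within the scatter) in this assay. Among the compounds shown here, this is the first pair that differs in one place, and it shows that this position can carry either group without a separable change in the reading. No measurement is available that would explain this result.

The compounds shown leave open whether an amine, a carboxylic acid or a longer chain such as ethoxy on this aromatic carbon would hold the reading as well. They also leave open whether compound 2 and compound 3 differ in potency, as a reading at one concentration does not give one.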